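The source may report more compounds than this note shows. Statements on the series, on what has been measured and on what is new or still open speak of the compounds shown alone.

Measured compounds:
- compound 1 `Clc1ccccc1-n1cc(CSc2nc3ccccc3s2)nn1` — 78.1%
- compound 2 `Fc1ccc(-n2cc(CSc3nc4ccccc4s3)nn2)cc1` — 81.1%
- compound 3 `c1ccc(-n2cc(CSc3nc4ccccc4s3)nn2)cc1` — 32.1%

These three share a core and differ only in the aromatic group attached to the aromatic nitrogen. In a functional assay on the whole organism (strain Albino Wistar) for inhibition, with Rattus norvegicus as the target, read by paw edema, with stated times of 1 h and 5 h, at a dose of 10 mg/kg by the oral route (a lower number here means less inhibition, a higher number more inhibition at the dose given (going by the name of the read-out)), compound 3 gives 32.1%, the lowest of the three numbers; the nearest of the others is compound 1, and the step of a number 46 percentage points lower from compound 1 to compound 3 (beyond the scatter) is large, as is a number 49 percentage points lower from compound 2 to compound 3 (beyond the scatter). Both steps show that removing a halogen from the phenyl ring lowers inhibition sharply, while a number 3 percentage points higher from compound 1 to compound 2 (within the scatter) shows that swapping one halogenated phenyl for another changes little.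

Compound 4 `c1cncc(-n2cc(CSc3nc4ccccc4s3)nn2)c1` takes a different kind of step from compound 3: pyridin-3-yl in place of phenyl on an aromatic nitrogen. Within the data shown here, no measured step exchanges a ring carbon for a ring nitrogen, so the two large steps into compound 3 do not bear directly on it, and the direction in this assay is open. Compound 4 is therefore expected to sit near compound 3, with a step of a number 12.9 percentage points higher from compound 3 to compound 4 (beyond the scatter) that may well be within the scatter. The estimate for compound 4 is 45%, with a range from 20% to 75%.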

Compound 4, a percentage reported as inhibition, in the whole organism at one dose (the size of the read-out at that dose, not a potency): 56%
Compound 4: middle estimate off by 11 percentage points, on the low side; the measured number falls inside the stated range.
By their numbers in this assay, from the lowest: compound 3; then compound 4; then compounds 1 and 2 (each within the scatter of the next).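

Swapping one ring carbon of the phenyl group for a ring nitrogen at this position also raises the number in this assay (a number 23.9 percentage points higher from compound 3 to compound 4 (beyond the scatter)), so the low value of compound 3 can be lifted without adding a halogen. The pyridin-3-yl group does not match either halogenated ring, however (a number 25.1 percentage points lower from compound 2 to compound 4 (beyond the scatter); a number 22.1 percentage points lower from compound 1 to compound 4 (beyond the scatter)), which places compound 4 in a middle tier of its own. Nothing available here explains why these changes shift the paw edema result.

The compounds shown leave open whether pyridin-2-yl or pyridin-4-yl would behave like pyridin-3-yl. They also leave open how a phenyl ring carrying an amine or a carboxylic acid would compare with the halogenated rings.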